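Swapping a fluorophenyl for a furan: cytotoxicity outlook

A few compounds are considered here, and "the series" means these few. Any claim that something is new, unique, unknown or untested is made for them only; others in the source may bear on it.

Compounds measured so far, with their values in an ADME assay on HeLa Rh cells (Homo sapiens) for cytotoxicity, read by microscopy; on this read-out lower numbers stand for higher toxicity in this test and higher numbers for lower toxicity in this test:
- compound 1, `COc1cc(CC(O)c2ccc(-c3ccc(CO)cc3)cc2)c([N+](=O)[O-])cc1OC`: > 244000 nM
- compound 2, `COc1cc(CC(O)c2ccc(-c3ccc(Br)cc3)cc2)c([N+](=O)[O-])cc1OC`: 4300 nM
- compound 3, `COc1cc(CC(O)c2ccc(-c3cccc(F)c3)cc2)c([N+](=O)[O-])cc1OC`: 7400 nM

The value of compound 1 is a limit of the assay, not a number (the limit of > 244000 nM in this assay, at which 1 of the 3 values shown sits). Among the two numbers known, compound 3 gives the highest, and its nearest neighbour is compound 2, the gap a 1.7-fold higher number from compound 2 to compound 3 (0.24 log units; within the scatter) lying within the scatter of this assay. The step of an at least 32-fold lower number from compound 1 to compound 3 (1.51 log units; beyond the scatter) was large.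

Compound 4, `COc1cc(CC(O)c2ccc(-c3ccoc3)cc2)c([N+](=O)[O-])cc1OC`, has not yet been tested. It differs from compound 3 in one place: furan-3-yl in place of 3-fluorophenyl on an aromatic carbon. Among the compounds with values here, only the step between compound 2 and compound 3 touches the same position with a ring kept intact, and it stayed within the scatter; the other step involved a hydroxymethyl group that compound 4 lacks. A step of moderate size toward a higher number is therefore expected, as a 2.0-fold higher number from compound 3 to compound 4 (0.31 log units; beyond the scatter). Compound 4 is estimated at 15000 nM, most likely between 4000 nM and 80000 nM.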

Compound 4, half-maximal cytotoxic concentration: 5300 nM
Compound 4: the middle estimate sits 2.8-fold (0.45 log units) above what was measured; the measured number falls inside the stated range.
By their numbers in this assay, from the lowest: compounds 2, 4 and 3 (each within the scatter of the next). At a limit, above all of these: compound 1.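

In this assay, moving to the five-membered furan-3-yl ring, which brings a hydrogen-bond acceptor, does not separate compound 4 from the compounds with a six-membered ring at this position: the change gives a 1.4-fold lower number from compound 3 to compound 4 (0.14 log units; within the scatter), and against the bromo compound it gives a 1.2-fold higher number from compound 2 to compound 4 (0.09 log units; within the scatter). Only the compound with the 4-(hydroxymethyl)phenyl group stands apart, with an at least 46-fold lower number from compound 1 to compound 4 (1.66 log units; beyond the scatter). The value of compound 1 is a limit of the assay, not a number: the limit of > 244000 nM in this assay, at which 1 of the 4 values shown sits.

Going by these compounds, it remains open whether that large step belongs to the hydroxymethyl group alone or would also appear with other groups on the end ring, such as an amine or a carboxylic acid. On these data alone, it is equally open whether a hydroxymethyl group on the furan ring would give the same result as on the phenyl ring.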